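The compounds below may be only part of what the source reports. "The series", "measured", "known", "first", "only" and "open" are said of these compounds alone.

Measured so far:
Compound 1, `O=C(CSc1nnc(-c2ccncc2)o1)N/N=C/c1ccc(Cl)cc1`: compound 1 gives 20500 nM in a functional assay on BGC-823 cells (Homo sapiens) for cytotoxicity, read by MTT assay, with a stated time of 48 h; on this read-out lower numbers stand for stronger inhibition and higher numbers for weaker inhibition.
Compound 2, `O=C(CSc1nnc(-c2ccncc2)o1)N/N=C/c1cc(Br)ccc1O`: compound 2 gives 9590 nM in this assay.

Compound 2 stands at the lowest of the two numbers in this assay, the nearest being compound 1. Compound 3, `O=C(CSc1nnc(-c2ccncc2)o1)N/N=C/c1cc(Br)cc(Br)c1O`, carries bromo in place of hydrogen on an aromatic carbon. Going by the values given here, the single measured step, a 2.1-fold lower number from compound 1 to compound 2 (0.33 log units; beyond the scatter), concerns a different exchange and does not directly cover adding bromo to compound 2; no measured pair shares this change. The expected step is therefore none beyond the scatter, a 1.3-fold lower number from compound 2 to compound 3 (0.11 log units; within the scatter), leaning if anything toward a slightly lower number. Compound 3 is estimated at 7500 nM, with a range of 2500 nM to 22000 nM.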

Compound 3, half-maximal inhibitory concentration: 9610 nM
Estimate against measurement, compound 3: 1.3-fold (0.11 log units) below; the range from low to high includes it.
By their numbers in this assay, from the lowest: compounds 2 and 3 (each within the scatter of the next); then compound 1.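

Bromo in place of hydrogen on the aromatic carbon ortho to the hydroxy group leaves the number unmoved in this assay, with a 1.0-fold higher number from compound 2 to compound 3 (0.00 log units; within the scatter) as the step. The 3,5-dibromo-2-hydroxyphenyl group still stands apart from 4-chlorophenyl, with a 2.1-fold lower number from compound 1 to compound 3 (0.33 log units; beyond the scatter) as the step, so this position accepts the added bromo without a measurable change. Nothing available explains this flat step.

From the compounds shown here alone, whether an amine or a carboxylic acid at this position would move the number remains open. The separate contributions of the hydroxy group and the 5-bromo group also remain unresolved.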